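The source may report more compounds than this note shows. Statements on the series, on what has been measured and on what is new or still open speak of the compounds shown alone.

Measured in a functional assay on HL-60 cells (Homo sapiens) for cytotoxicity; on this read-out higher numbers stand for lower toxicity in this test and lower numbers for higher toxicity in this test:
compound 1 `COc1ccc(/C=C2\Cc3ccccc3/C(=C\c3ccc([N+](=O)[O-])cc3)C2=O)cc1` gives 4400 nM
compound 2 `O=C1/C(=C/c2ccc(O)cc2)Cc2ccccc2/C1=C\c1ccc([N+](=O)[O-])cc1` gives 2500 nM
compound 3 `O=C1/C(=C/c2ccc(O)cc2)CCC/C1=C\c1ccc([N+](=O)[O-])cc1` gives 4400 nM

Compound 4 `COc1ccc(/C=C2\CCC/C(=C\c3ccc([N+](=O)[O-])cc3)C2=O)cc1` has not yet been measured. Compound 2 and compound 3 differ in their cores; the difference between the two cores is not broken down here. The value of compound 3 matches that of compound 1 at the digits read, and the values of compound 2 and compound 3 lie within the usual scatter of each other. Compound 1 differs from compound 2 by methyl in place of hydrogen on an oxygen on an aromatic ring, and compound 4 differs from compound 3 by methyl in place of hydrogen on an oxygen on an aromatic ring: the same change at the same place. On the core of compound 2 the change gave a 1.8-fold higher number from compound 2 to compound 1 (0.25 log units; within the scatter). On the core of compound 3 a step of similar small size is expected, a 1.4-fold higher number from compound 3 to compound 4 (0.13 log units; within the scatter), because the single measured case is a 1.8-fold higher number from compound 2 to compound 1 (0.25 log units; within the scatter) and lies within the scatter. Compound 4 is therefore estimated at 6000 nM, with a likely range from 2500 nM to 14000 nM.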

Compound 4, half-maximal cytotoxic concentration: > 400000 nM
Compound 4 gave a limit, no number (the forecaster's own chance of this, stated with the estimate: 5%); middle value at least 66-fold (1.82 log units) from the limit.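

In this assay, methyl in place of hydrogen on the oxygen gives an at least 90-fold higher number from compound 3 to compound 4 (1.95 log units; beyond the scatter), and a step of this size does not carry over from the other core: the same change on two cores in this assay, a 1.8-fold higher number (0.25 log units; within the scatter) from compound 2 to compound 1 and an at least 90-fold higher number (1.95 log units; beyond the scatter) from compound 3 to compound 4, at least 51-fold (1.71 log units) apart, beyond the scatter of two such steps
Compound 4 stands at > 400000 nM, which is a limit of the assay and not a number: the limit of > 400000 nM in this assay, at which 1 of the 4 values shown sits.
The two pairs show that this change cannot be assumed to read the same on both cores, but they do not show the true size of the step on the core of compound 3 or which part of the core difference goes with the gap.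

With one pair per core, no rule for the series can be drawn. Still open, from the compounds shown here alone, is how an ethyl group or a longer chain on that oxygen, or an amine in place of the hydroxy, would read on each core.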